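Stereoisomer step from compound 2 to compound 4

The source may hold more compounds than are shown below. What is called first, only, known or untested is meant among the compounds shown, and "the series" means these compounds.

Measured so far:
- compound 1, `O=C(/C=C/c1ccc(O)cc1)O[C@H]1[C@H](O[C@@H]2CCCC[C@H]2O)O[C@H](CO)[C@@H](O)[C@@H]1O`; in a functional assay on HCT-15 cells (Homo sapiens) for cytotoxicity, read by sulforhodamine B assay (a higher number here means a weaker inhibitor, a lower number a stronger inhibitor), compound 1 is reported only as a limit, > 10000 nM.
- compound 2, `O=C(/C=C\c1ccc(O)cc1)O[C@H]1[C@H](O[C@@H]2CCCC[C@H]2O)O[C@H](CO)[C@@H](O)[C@@H]1O`; in this assay compound 2 is reported only as a limit, > 10000 nM.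
- compound 3, `O=C(OC[C@H]1O[C@@H](O[C@@H]2CCCC[C@H]2O)[C@H](O)[C@@H](O)[C@@H]1O)c1ccc(O)cc1`; in this assay compound 3 is reported only as a limit, > 10000 nM.

Compound 2 stands at a limit, as do the other two values shown; no number separates any of them, and the step that the two limits leave unreadable from compound 1 to compound 2 is unreadable because of the limit of > 10000 nM in this assay, at which 3 of the 3 values shown sit.

Compound 4, `O=C(/C=C/c1ccc(O)cc1)O[C@H]1[C@H](O[C@H]2CCCC[C@@H]2O)O[C@H](CO)[C@@H](O)[C@@H]1O`, differs from compound 2 as follows: the two compounds have the same atoms and bonds and differ only in configuration as drawn: 3 of 8 stereo elements differ; a stereocentre at a saturated ring carbon is drawn R in compound 2 and S in compound 4; a stereocentre at a saturated ring carbon is drawn R in compound 2 and S in compound 4; a double bond is drawn Z in compound 2 and E in compound 4. Compound 1 and compound 4 share the E double bond and compound 1 sits at the same limit, so nothing measured points to a readable step. Compound 4 is expected to stay at the limit, with the step that the limit leaves unreadable from compound 2 to compound 4 estimated as none beyond the scatter. The estimate for compound 4 is 15000 nM, between 8000 nM and 40000 nM.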

Compound 4, half-maximal inhibitory concentration: > 10000 nM
Compound 4 gave a limit, no number; the forecaster's own chance of this, stated with the estimate: 85%; the middle value lies beyond the limit too.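

In this assay compound 4 gives > 10000 nM, a limit and not a number. The steps to it from compound 1 and compound 2 cannot be read. The compounds shown leave open whether double-bond or ring-carbon configuration affects cytotoxicity at all.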